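Swapping phenylsulfonyl for benzoyl on compound 3

The source may report more compounds than this note shows. Statements on the series, on what has been measured and on what is new or still open speak of the compounds shown alone.

Compounds 1, 2 and 3 share one core and differ in a single group on a saturated ring carbon. In an ADME assay on cells (Hepatocyte, Mus musculus) for metabolic stability, with a stated time of 30 min (a higher number here means that more of the compound is left, a lower number that less of the compound is left), compound 1 `O=C(OC1CCC(CN2CCN(c3cc(=O)c4cc(C(F)(F)F)cc([N+](=O)[O-])c4s3)CC2)CC1)c1ccccc1` gives 68.1% while compound 2 `NC1CCC(CN2CCN(c3cc(=O)c4cc(C(F)(F)F)cc([N+](=O)[O-])c4s3)CC2)CC1` gives 107% and compound 3 `O=c1cc(N2CCN(CC3CCC(NS(=O)(=O)c4ccccc4)CC3)CC2)sc2c([N+](=O)[O-])cc(C(F)(F)F)cc12` gives 95.3% as the second highest of the three.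

Compound 4 `O=C(NC1CCC(CN2CCN(c3cc(=O)c4cc(C(F)(F)F)cc([N+](=O)[O-])c4s3)CC2)CC1)c1ccccc1` has not been measured yet. It carries benzoyl in place of phenylsulfonyl on an amine nitrogen, and the exchange benzoyl in place of phenylsulfonyl on an amine nitrogen keeps the aromatic ring in place.

Three measured steps frame this change. The large a number 38.9 percentage points higher from compound 1 to compound 2 (beyond the scatter) and the modest a number 27.2 percentage points higher from compound 1 to compound 3 (beyond the scatter) both leave a benzoyloxy group behind. The modest a number 11.7 percentage points lower from compound 2 to compound 3 (beyond the scatter) adds phenylsulfonyl to the free amine. Going by the values given here, no measured compound has benzoyl on nitrogen, so the comparison remains indirect. Compound 4 shares its nitrogen link with compound 3, so a small drop is expected, and the estimated a number 5.3 percentage points lower from compound 3 to compound 4 (within the scatter) in this assay would not clearly exceed the scatter. For compound 4 the estimated value is 90% with an expected range from 73% to 106% in this test.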

Compound 4, percent of the compound remaining: 90.6%
The estimate for compound 4 lay 0.6 percentage points below the measured number; measured number inside the range.
By their numbers in this assay, from the lowest: compound 1; then compounds 4 and 3 (each within the scatter of the next); then compound 2.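

Benzoyl in place of phenylsulfonyl on this amine nitrogen gives a number 4.7 percentage points lower from compound 3 to compound 4 (within the scatter), so this assay does not separate the two groups here. The new compound also shows that the drop from the free amine is not confined to phenylsulfonyl: benzoyl on the same nitrogen gives a number 16.4 percentage points lower from compound 2 to compound 4 (beyond the scatter). Compounds 1 and 4 also form a closer pair than those measured before, since both carry the benzoyl carbonyl and the aromatic ring, and benzamido in place of benzoyloxy on the saturated ring carbon gives a number 22.5 percentage points higher from compound 1 to compound 4 (beyond the scatter).

Still open, as far as these compounds go, is how this assay would read with an acetyl group on this nitrogen, or with a methyl on the amide nitrogen of compound 4. Nothing measured here explains any of these differences.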